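The source may report more compounds than this note shows. Statements on the series, on what has been measured and on what is new or still open speak of the compounds shown alone.

Measured so far in an assay on liver for inhibition of sterol O-acyltransferase 1 (Rattus norvegicus), using microsomes; a lower number here means a stronger inhibitor, a higher number a weaker inhibitor:

compound 1, `CC(C)(C)c1cccc(C(C)(C)C)c1OC(=O)NS(=O)(=O)Nc1ccccc1`: compound 1 gives 19000 nM
compound 2, `CC(C)c1cccc(C(C)C)c1NS(=O)(=O)NC(=O)Oc1c(C(C)(C)C)cccc1C(C)(C)C`: compound 2 gives 16800 nM
compound 3, `Cc1cc(C(C)(C)C)c(OC(=O)NS(=O)(=O)Nc2ccccc2)c(C(C)(C)C)c1`: compound 3 gives 23400 nM

Working notes. Compound 3 is derived from compound 1 by the change methyl in place of hydrogen on an aromatic carbon
and the measured step for that change is a 1.2-fold higher number from compound 1 to compound 3 (0.09 log units; within the scatter). Compound 2 carries a different core; how its core differs from that of compound 1 is not broken down here, and the two values alone show that compound 2 and compound 1 stand within the scatter of one another. Compound 2 also stands within the scatter of compound 3. With every pair inside the usual scatter, none of the three can be called stronger or weaker than the others in this assay.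

Compound 4, `Cc1cc(C(C)(C)C)c(OC(=O)NS(=O)(=O)Nc2c(C(C)C)cccc2C(C)C)c(C(C)(C)C)c1`, is not yet measured. It is derived from compound 2 by the change methyl in place of hydrogen on an aromatic carbon
which is the same change as the one from compound 1 to compound 3, and the surroundings of the place are described in identical words in both cases. The expected step is a 1.2-fold higher number from compound 2 to compound 4 (0.08 log units; within the scatter), which rests on the measured step of a 1.2-fold higher number from compound 1 to compound 3 (0.09 log units; within the scatter) being within the scatter. Within the data shown here, only one measured instance of this change exists, so the bracket is kept wide. For compound 4 the estimated value in this assay is 20000 nM, expected to lie between 9000 nM and 45000 nM.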

Compound 4, half-maximal inhibitory concentration: 13500 nM
For compound 4 the middle estimate is 1.5-fold (0.17 log units) above the measured one, within the range that was stated.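

In this assay, methyl in place of hydrogen on an aromatic carbon, meta to two tert-butyl groups and para to a large group, gives a 1.2-fold lower number from compound 2 to compound 4 (0.09 log units; within the scatter). Set beside the earlier instance of the same change, the two steps do not differ: the same change on two cores in this assay, a 1.2-fold higher number (0.09 log units; within the scatter) from compound 1 to compound 3 and a 1.2-fold lower number (0.09 log units; within the scatter) from compound 2 to compound 4, 1.5-fold (0.19 log units) apart, within the scatter of two such steps. This shows that on these two cores the change leaves the number inside the scatter both times, but with neither step beyond the scatter, the pair cannot show that a measurable effect of the methyl carries from one core to another, and two instances say nothing about further cores in the series.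

Going by these compounds, it remains open whether a different group at this aromatic carbon, such as methoxy, chlorine, an amine or a carboxylic acid, would give a step beyond the scatter in this assay, and whether such a step would then hold on both cores. Also open is how the number in this assay responds when the two tert-butyl groups give way to a longer chain such as n-hexyl, a change for which the compounds shown offer no instance.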